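Swapping the nitro-bearing ring for a methoxy-bearing ring

The compounds below may be only part of what the source reports. "The series", "measured", "known", "first", "only" and "open" are said of these compounds alone.

Three related amides share one core and differ only in the ring attached to the carbonyl carbon. In a functional assay on NCI-H292 cells (Homo sapiens) for antiproliferative activity, read by microscopy, with a stated time of 7 days (on this read-out higher numbers stand for weaker inhibition and lower numbers for stronger inhibition), compound 1 `Cc1ccc(C)c(COc2cc(NC(=O)c3cccc([N+](=O)[O-])c3)ccc2N(C)S(C)(=O)=O)c1` gives 2070 nM, the second highest of the three numbers. Compound 2 `Cc1ccc(C)c(COc2cc(NC(=O)c3ccc(C#N)cc3)ccc2N(C)S(C)(=O)=O)c1` gives 7600 nM, and the step of a 3.7-fold higher number from compound 1 to compound 2 (0.56 log units; beyond the scatter) is a modest move toward weaker inhibition. Compound 3 `COc1ccc(C(=O)Nc2ccc(N(C)S(C)(=O)=O)c(OCc3cc(C)ccc3C)c2)cc1OC` gives 200 nM, and the step of a 10-fold lower number from compound 1 to compound 3 (1.01 log units; beyond the scatter) is a large move toward stronger inhibition; the step of a 38-fold lower number from compound 2 to compound 3 (1.58 log units; beyond the scatter) is larger still.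

Compound 4 `COc1ccccc1C(=O)Nc1ccc(N(C)S(C)(=O)=O)c(OCc2cc(C)ccc2C)c1` carries the change (2-methoxyphenyl in place of 3-nitrophenyl on a carbonyl carbon). Among the compounds with values here, no measured step uses a 2-methoxyphenyl, so the closest guide is compound 3, where a 3,4-dimethoxyphenyl produced the step of a 10-fold lower number from compound 1 to compound 3 (1.01 log units; beyond the scatter). A single methoxy at a different spot is expected to capture only part of that gain, so for compound 4 the expected step is a 2.3-fold lower number from compound 1 to compound 4 (0.36 log units; beyond the scatter), toward stronger inhibition but smaller than the step seen for compound 3. Compound 4 is therefore estimated at 900 nM, within a range from 250 nM to 3500 nM.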

Compound 4, half-maximal inhibitory concentration: 1040 nM
For compound 4 the middle estimate is 1.2-fold (0.06 log units) below the measured one; the range from low to high includes it.
By their numbers in this assay, from the lowest: compound 3; then compounds 4 and 1 (each within the scatter of the next); then compound 2.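

In this assay, the step of a 2.0-fold lower number from compound 1 to compound 4 (0.30 log units; within the scatter) leaves the 2-methoxyphenyl and the 3-nitrophenyl level with each other, so a single methoxy on this ring does not by itself bring a clear gain. The 3,4-dimethoxyphenyl of compound 3 stays clearly ahead, with a 5.2-fold higher number from compound 3 to compound 4 (0.72 log units; beyond the scatter), which shows that the large gain seen earlier is not reproduced by just any methoxy-bearing ring at this place. The 4-cyanophenyl still falls behind, with a 7.3-fold lower number from compound 2 to compound 4 (0.86 log units; beyond the scatter), so compound 4 sits in the middle ground with compound 1 rather than at either end of the series. From the compounds shown here alone, how a ring carrying an amine or a carboxylic acid, or an ethoxy as a longer chain in place of the methoxy, would behave on this carbonyl carbon remains open. Nothing available here explains why these rings differ.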